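The compounds below may be only part of what the source reports. "The series", "measured", "known", "first", "only" and "open" are said of these compounds alone.

Measured so far:
Compound 1, `O=C(O)Cc1sc(C(c2ccccc2)c2ccccc2)nc1-c1ccc(F)cc1`: 77 nM
Compound 2, `O=C(O)Cc1sc(C(c2ccccc2)c2ccccc2)nc1-c1ccc(F)c(F)c1`: 43 nM

In an in vitro functional assay on HEK285-7 cells for antagonist activity at prostaglandin D2 receptor 2 (Homo sapiens), read by BRET and beta-arrestin recruitment (on this read-out lower numbers stand for stronger inhibition and higher numbers for weaker inhibition), compound 1 gives 77 nM and compound 2 gives 43 nM. Within the data shown here, the one step measured, a 1.8-fold lower number from compound 1 to compound 2 (0.25 log units; within the scatter), comes from a fluoro in place of hydrogen on an aromatic carbon and lies within the scatter, so the two compounds cannot be told apart on these numbers. Compound 3, `O=C(O)Cc1sc(C(c2ccccc2)c2ccccc2)nc1-c1ccc(C(F)(F)F)cc1`, carries a different aryl group on the shared core: 4-(trifluoromethyl)phenyl in place of 3,4-difluorophenyl on an aromatic carbon. Among the measured compounds shown here, the only step that bears on this change is the one from compound 1 to compound 2, which swaps substituents on the same aromatic ring and moved the number by less than the scatter. On that basis no step beyond the scatter is expected. For compound 3 the value in this assay is estimated at 60 nM, within a range of 20 nM to 180 nM. This estimate means a step of a 1.4-fold higher number from compound 2 to compound 3 (0.14 log units; within the scatter), expected to stay within the scatter.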

Compound 3, half-maximal inhibitory concentration: > 100000 nM
Compound 3 gave a limit, no number; the forecaster's own chance of this, stated with the estimate: 5%; at least 1600-fold (3.22 log units) between middle value and limit.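

In this assay, compound 3 gives a limit of the assay, not a number: the limit of > 100000 nM in this assay, at which 1 of the 3 values shown sits. The aromatic carbon next to the ring nitrogen therefore does not accept every aryl group: 4-(trifluoromethyl)phenyl in place of 3,4-difluorophenyl brings an at least 2300-fold higher number from compound 2 to compound 3 (3.36 log units; beyond the scatter), and trifluoromethyl in place of fluoro brings an at least 1200-fold higher number from compound 1 to compound 3 (3.11 log units; beyond the scatter). Compound 1 and compound 2 both keep a phenyl ring with fluoro there and give measurable numbers, so among these three compounds the loss goes with the trifluoromethyl group, not with having an aryl ring at this place.

These compounds give no cause for the step. As far as these compounds go, whether a methyl or chloro group in place of the trifluoromethyl would restore a measurable number remains open.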